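The source may hold more compounds than are shown below. What is called first, only, known or untested is meant among the compounds shown, and "the series" means these compounds.

In a functional assay on DU-145 cells (Homo sapiens) for inhibition, read by trypan blue exclusion, with a stated time of 72 h (a higher number here means a weaker inhibitor, a lower number a stronger inhibitor), three compounds have been measured:

Compound 1 `Cn1c(=O)c(S(=O)(=O)Cc2ccc(F)cc2)cc2cnc(Nc3ccc4[nH]ccc4c3)nc21`: 30000 nM
Compound 2 `Cc1ccc(S(=O)(=O)c2cc3cnc(Nc4cccc5cccnc45)nc3n(C)c2=O)cc1`: 10000 nM
Compound 3 `Cc1ccc(S(=O)(=O)c2cc3cnc(Nc4ccc5cc[nH]c5c4)nc3n(C)c2=O)cc1`: 15000 nM

Compound 1 carries the highest of the three numbers; compound 3 sits within the scatter of it, while the gap to compound 2 lies beyond the scatter. Among the measured compounds shown here, the single measured step, a 1.5-fold higher number from compound 2 to compound 3 (0.18 log units; within the scatter), concerns the group on the amine nitrogen and not the sulfonyl group. Compound 4 `Cn1c(=O)c(S(=O)(=O)c2ccc(O)cc2)cc2cnc(Nc3ccc4[nH]ccc4c3)nc21` differs from compound 1 by 4-hydroxyphenyl in place of 4-fluorobenzyl on a sulfonyl sulfur. For the measured compounds named here, no measured step touches the sulfonyl substituent, so nothing in the data points in either direction, and the expected step is a 1.4-fold lower number from compound 1 to compound 4 (0.13 log units; within the scatter), within the scatter. Compound 4 is therefore estimated at 22000 nM in this assay, with a range from 6000 nM to 70000 nM.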

Compound 4, half-maximal inhibitory concentration: 250 nM
For compound 4 the middle estimate is 88-fold (1.94 log units) above the measured one, outside the stated range (below it).
By their numbers in this assay, from the lowest: compound 4; then compounds 2, 3 and 1 (each within the scatter of the next, the first and the last beyond it).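

The sulfonyl substituent proves to be a sensitive position in this assay: 4-hydroxyphenyl in place of 4-fluorobenzyl on the sulfonyl sulfur gives a 120-fold lower number from compound 1 to compound 4 (2.08 log units; beyond the scatter) with the rest of the molecule unchanged. The earlier step, on the amine nitrogen, stayed within the scatter and gave no sign of a change this large. Nothing available accounts for its size.

Because benzyl becomes phenyl and fluoro becomes hydroxy in one step, the compounds shown leave open which of the two matters. From the compounds shown here alone, a 4-fluorophenyl or 4-hydroxybenzyl group would separate them, and whether a 4-methoxyphenyl or 4-aminophenyl group would behave like 4-hydroxyphenyl also remains open.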